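Exchanging the aryl group on the urea nitrogen: compound 3 to compound 4

A few compounds are considered here, and "the series" means these few. Any claim that something is new, unique, unknown or untested is made for them only; others in the source may bear on it.

Compound 3 `COc1cc(Cl)cc(-c2nn(-c3cccc(NC(=O)Nc4ccc(Cl)c(Cl)c4)c3)cc2-c2ccncc2)c1` gives 100% in a functional assay on OVCAR-3 cells (Homo sapiens) for inhibition, read by sulforhodamine B assay, with a stated time of 48 h, tested at 0.01 uM; on this read-out lower numbers stand for a stronger effect and higher numbers for a weaker effect at the one concentration tested. Among the three numbers measured so far it is the second highest: compound 2 `COc1cc(Cl)cc(-c2nn(-c3cccc(NC(=O)Nc4cc(C(F)(F)F)cc(C(F)(F)F)c4)c3)cc2-c2ccncc2)c1` gives 105%, and compound 1 `COc1cc(Cl)cc(-c2nn(-c3cccc(NC(=O)Nc4ccc(Cl)c(C(F)(F)F)c4)c3)cc2-c2ccncc2)c1` gives 91%; both of these lie within the scatter of compound 3, so the three cannot be told apart on this read-out. The move from compound 3 to compound 4 `COc1cc(Cl)cc(-c2nn(-c3cccc(NC(=O)Nc4cccc(C(F)(F)F)c4)c3)cc2-c2ccncc2)c1` is 3-(trifluoromethyl)phenyl in place of 3,4-dichlorophenyl on an amide-type nitrogen. Going by the values given here, the only measured step that touches the same part of the molecule is a number 9 percentage points higher from compound 1 to compound 3 (within the scatter), and it did not carry the number beyond the scatter. With every measured number sitting within the scatter of the others, nothing in these data gives reason to expect the change to compound 4 to move the read-out noticeably. For compound 4 the expected step is a number 3 percentage points lower from compound 3 to compound 4 (within the scatter), none beyond the scatter. Compound 4 is estimated at 97%, with a range from 82% to 112%.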

Compound 4, a percentage reported as activity, at one concentration (the size of the read-out at that concentration, not a potency): 100%
The estimate for compound 4 lay 3 percentage points below the measured number; the measured number falls inside the stated range.
By their numbers in this assay, from the lowest: compounds 1, 3, 4 and 2 (each within the scatter of the next, the first and the last beyond it).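

In this assay the exchange of 3,4-dichlorophenyl for 3-(trifluoromethyl)phenyl on the amide-type nitrogen gives no change at the digits printed from compound 3 to compound 4 (within the scatter) and so adds a further aryl group that cannot be told apart from the others. Going by these compounds alone, the two single-group steps show something the earlier compounds did not: taking away the second ring substituent leaves the read-out within the scatter, whether that substituent is trifluoromethyl, with a number 5 percentage points lower from compound 2 to compound 4 (within the scatter) or chloro, with a number 9 percentage points higher from compound 1 to compound 4 (within the scatter) as the step. Nothing in the data accounts for this flat result.

The compounds shown leave open whether a ring carrying an amine or a carboxylic acid, or a longer alkyl chain on this nitrogen in place of the aryl group, would move the number beyond the scatter. They also leave open whether these aryl groups can be told apart at other concentrations.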